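A few compounds are considered here, and "the series" means these few. Any claim that something is new, unique, unknown or untested is made for them only; others in the source may bear on it.

Compound 1 `COCCNc1nc(-c2ccccc2)nc2ccccc12` gives 26.8 ug/mL
Compound 2 `CN1CCCN(c2nc(-c3ccccc3)nc3ccccc23)CC1` gives 20.1 ug/mL

In a functional assay on HCT-15 cells (Homo sapiens) for cytotoxicity, read by sulforhodamine B assay (a lower number here means a stronger inhibitor, a higher number a weaker inhibitor), compound 2 gives 20.1 ug/mL. Within the data shown here, only one other compound has a number so far, and the two sit together: a 1.3-fold lower number from compound 1 to compound 2 (0.12 log units; within the scatter). Compound 3 `COC(=O)CNc1nc(-c2ccccc2)nc2ccccc12` has not yet been measured. It carries ((methoxycarbonyl)methyl)amino in place of 4-methyl-1,4-diazepan-1-yl on an aromatic carbon. The place is on the six-membered aromatic ring with 2 nitrogen, and the entering group has no ring. Among the measured compounds shown here, compound 1 also has an open chain there, (2-methoxyethyl)amino, so the one measured step bears directly on this change. That step, a 1.3-fold lower number from compound 1 to compound 2 (0.12 log units; within the scatter), joined an open chain and the same ring group and stayed small. For the measured compounds named here, no measured compound carries the methoxycarbonyl part, so this evidence is thin and the range must stay wide. In this assay no change beyond the scatter is therefore expected, in either direction. The expected step is a 1.2-fold higher number from compound 2 to compound 3 (0.08 log units; within the scatter). For compound 3 the estimated value is 24 ug/mL, with an expected range from 10 ug/mL to 55 ug/mL.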

Compound 3, half-maximal inhibitory concentration: 37.5 ug/mL
Compound 3: middle estimate off by 1.6-fold (0.19 log units), on the low side, and the stated range covers the measured number.
By their numbers in this assay, from the lowest: compounds 2, 1 and 3 (each within the scatter of the next).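

In this assay, replacing the ring-bearing 4-methyl-1,4-diazepan-1-yl with the open-chain ((methoxycarbonyl)methyl)amino gives a 1.9-fold higher number from compound 2 to compound 3 (0.27 log units; within the scatter), so a third group on this aromatic carbon also leaves the number inside the scatter. Among these compounds, the comparison between the two open chains, with methoxycarbonyl in place of methoxymethyl on the saturated chain carbon bound to the nitrogen, gives a 1.4-fold higher number from compound 1 to compound 3 (0.15 log units; within the scatter), which is the first reading for a chain with a carbonyl at this place and shows no separation from the ether chain either. Thus the seven-membered ring and both open chains cannot be told apart here, and nothing measured for these compounds offers a reason for these small steps.

On these data alone, it remains open whether any group at this place can move the number beyond the scatter, for example a carboxylic acid in place of the methoxycarbonyl, a plain amine or a longer chain. All three compounds also keep the same phenyl group and the same shared core, so they say nothing about changes at those parts.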